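This account rests on a few compounds, and the source may have more. Where it says the series, first, only, none or still open, it means among the compounds named here.

In this assay, an assay for inhibition of Polyunsaturated fatty acid 5-lipoxygenase (Homo sapiens), read by spectrophotometry, in the presence of a further agent that is not named here (on this read-out higher numbers stand for weaker inhibition and lower numbers for stronger inhibition), compound 1 `Cc1nc(NC(=O)c2ccccc2)sc1C(=O)/C=C/c1ccc(F)cc1` gives 140 nM, the lowest of the two numbers in hand. Compound 2 `COc1ccc(C(=O)Nc2nc(C)c(C(=O)/C=C/c3ccc(F)cc3)s2)cc1` gives 560 nM. Within the data shown here, the only measured step, a 4.0-fold higher number from compound 1 to compound 2 (0.60 log units; beyond the scatter), is a methoxy in place of hydrogen on an aromatic carbon, and it lies beyond the scatter.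

Compound 3 `Cc1nc(NC(=O)c2ccccc2)sc1C(=O)/C=C/c1cccc([N+](=O)[O-])c1` has not been measured in this assay. It differs from compound 1 by 3-nitrophenyl in place of 4-fluorophenyl on a double-bonded chain carbon bound to a double-bonded chain carbon. Among the measured compounds shown here, the step from compound 1 to compound 2 sits elsewhere on the shared core and does not concern the aryl group on the chain; no measured step bears on the change to compound 3. With nothing to set a direction, the expectation in this assay is a step within the scatter, a 1.4-fold higher number from compound 1 to compound 3 (0.15 log units; within the scatter). Compound 3 is therefore estimated at 200 nM, with a range from 60 nM to 700 nM to cover the missing precedent.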

Compound 3, half-maximal inhibitory concentration: 240 nM
For compound 3 the middle estimate is 1.2-fold (0.08 log units) below the measured one; the measured number falls inside the stated range.
By their numbers in this assay, from the lowest: compounds 1 and 3 (each within the scatter of the next); then compound 2.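

Among these compounds, this is the first change seen at the aryl group on the chain: in this assay, 3-nitrophenyl in place of 4-fluorophenyl gives a 1.7-fold higher number from compound 1 to compound 3 (0.23 log units; within the scatter), so this exchange does not separate the two compounds. The place on a double-bonded chain carbon therefore accepts a group with hydrogen-bond acceptors, which 4-fluorophenyl lacks, and a substituent in a different ring location without a step beyond the scatter, although the two differences arrive together and cannot be told apart here. No supporting data bear on why the number holds across this exchange.

The compounds shown leave open whether the nitro group or the fluorine matters at all, as neither unsubstituted phenyl nor 4-nitrophenyl appears among them. Going by these compounds, it also remains open whether an amine or a carboxylic acid on this aryl ring would stay within the scatter of compound 1.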